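A few compounds are considered here, and "the series" means these few. Any claim that something is new, unique, unknown or untested is made for them only; others in the source may bear on it.

Compound 1 `COCCNC(=O)CNc1ncc2c(Br)nn(-c3ccc4ncccc4c3)c2n1` and compound 2 `COCCNC(=O)CCNc1ncc2c(Br)nn(-c3ccc4ncccc4c3)c2n1` share the core of this series. In an assay on SK-OV-3 cells for inhibition of eIF-2-alpha kinase GCN2 (Homo sapiens) (on this read-out lower numbers stand for stronger inhibition and higher numbers for weaker inhibition), compound 1 gives "nd" (no result reported) and compound 2 gives "nd" (no result reported), so nothing can be said of them. Compound 3 `Brc1nn(-c2ccc3ncccc3c2)c2nc(N[C@@H]3CC[C@@H](c4ncc[nH]4)C3)ncc12` therefore stands alone: in this assay compound 3 gives 545 nM, the only number shown for the whole set. Compound 4 `CS(=O)(=O)N1CC[C@@H](Nc2ncc3c(Br)nn(-c4ccc5ncccc5c4)c3n2)C1` differs from compound 3 in one place, (a group of 9 heavy atoms (5 carbon, 1 nitrogen, 2 oxygen, 1 sulfur; one five-membered non-aromatic ring with 1 hetero atom) in place of a group of 10 heavy atoms (8 carbon, 2 nitrogen; one five-membered non-aromatic ring of carbon only, one five-membered aromatic ring with 2 hetero atoms), on a nitrogen on an aromatic ring). Among the compounds with values here, no step between two measured compounds exists to guide the size of this change. The expected step is a modest one, a 2.4-fold higher number from compound 3 to compound 4 (0.38 log units; beyond the scatter), toward weaker inhibition, of a size only slightly beyond the usual scatter. For compound 4 in this assay the estimated value is 1300 nM, with a plausible range from 300 nM to 5000 nM.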

Compound 4, half-maximal inhibitory concentration: 378 nM
The estimate for compound 4 lay 3.4-fold (0.54 log units) above the measured number, and the stated range covers the measured number.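

Placed on the nitrogen on an aromatic ring, the 1-(methylsulfonyl)pyrrolidin-3-yl group replaces a group built quite differently, and this assay shows a 1.4-fold lower number from compound 3 to compound 4 (0.16 log units; within the scatter). The first step available at this position therefore shows that two unlike groups can give numbers within the usual scatter of each other. Nothing shown explains why these two groups read alike. On these data alone, whether a piperidine ring or a simple amine at this position would also match remains open. The effect of reversing the defined stereocentre of the pyrrolidine ring is also unknown.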